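A few compounds are considered here, and "the series" means these few. Any claim that something is new, unique, unknown or untested is made for them only; others in the source may bear on it.

Working notes on the tetrazole series.

Two compounds have been run so far. Compound 1 `CC(C)(N)C(=O)N[C@H](COCc1ccccc1)c1nnnn1CCCCC#N` gives 35 nM in a functional assay on H4 cells for agonist activity at growth hormone secretagogue receptor type 1 (Homo sapiens), read by FLIPR; a lower number here means that less compound is needed, a higher number that more compound is needed for the effect. Compound 2 `CC(C)(N)C(=O)N[C@H](COCc1ccccc1)c1nnnn1CCC#N` gives 30 nM in this assay. Going by the values given here, the one step between them, a 1.2-fold lower number from compound 1 to compound 2 (0.07 log units; within the scatter), shortens the chain on the aromatic nitrogen without moving the number beyond the scatter, so compound 2 and compound 1 sit level with each other on the two numbers in hand.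

Compound 3 `CCCCNC(=O)CCn1nnnc1[C@@H](COCc1ccccc1)NC(=O)C(C)(C)N` is next. Relative to compound 2 the change is butylcarbamoyl in place of cyano on a saturated chain carbon, two bonds along the chain from an aromatic nitrogen. Among the compounds with values here, no measured step alters the group at the chain end in this way; the only step on hand, a 1.2-fold lower number from compound 1 to compound 2 (0.07 log units; within the scatter), touches the length of the chain rather than its terminal group and was flat. That flat step gives the sole hint that this part of the molecule tolerates alteration, but a nitrile-to-amide exchange with a butyl tail is a larger change than anything tested, so a modest loss is estimated rather than assumed flatness. The expected step is a 1.8-fold higher number from compound 2 to compound 3 (0.26 log units; within the scatter). Compound 3 is therefore estimated at 55 nM in this assay, within a range of 15 nM to 200 nM.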

Compound 3, half-maximal effective concentration: 42 nM
Estimate against measurement, compound 3: 1.3-fold (0.12 log units) above, within the range that was stated.
By their numbers in this assay, from the lowest: compounds 2, 1 and 3 (each within the scatter of the next).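

At this place, on a saturated chain carbon, two bonds along the chain from an aromatic nitrogen, the terminal group itself can now be read and not only the chain length: in this assay the exchange of cyano for butylcarbamoyl gives a 1.4-fold higher number from compound 2 to compound 3 (0.15 log units; within the scatter), although 7 heavy atoms enter where 2 leave and 1 hydrogen-bond donor is added. Against the longer nitrile, the same comparison gives a 1.2-fold higher number from compound 1 to compound 3 (0.08 log units; within the scatter), so all three compounds sit level and neither the nitrile nor the butyl amide can be ranked above the other. The numbers show tolerance of this change across these three compounds only, and no measurement on hand explains that tolerance.

Still open, on these data alone, is whether the level numbers extend to a chain end bearing a carboxylic acid, a primary amine or a phenyl ring, or to a tertiary amide carrying a methyl group on the amide nitrogen. Also open, as far as these compounds go, is how far the butyl tail can be lengthened or shortened before a step beyond the scatter appears.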